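Methoxy to Nitro on a Pentyl Aminobenzimidazole Core

A few compounds are considered here, and "the series" means these few. Any claim that something is new, unique, unknown or untested is made for them only; others in the source may bear on it.

Of the compounds shown here, three sharing a core have been tested in an assay on HEK293 cells for agonist activity at Toll-like receptor 8 (Homo sapiens), read by reporter gene assay; a lower number here means that less compound is needed, a higher number that more compound is needed for the effect. Compound 1 `Nc1nc2ccccc2n1Cc1ccccc1` carries a benzyl on the ring nitrogen and is reported as "not active" (no number reported). Within the data shown here, compound 2 `CCCCCn1c(N)nc2c(OC)cccc21` carries a pentyl chain and a methoxy group and gives 3740 nM, the only number in the set. Compound 3 `CCCCCn1c(N)nc2c(OCc3ccccc3)cccc21` keeps the pentyl chain but carries a benzyloxy group and is reported as "not active" (no number reported). Among the measured compounds shown here, compound 2 therefore stands alone as the one member with a measured concentration, and no step between two measured values is available.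

Compound 4 `CCCCCn1c(N)nc2c([N+](=O)[O-])cccc21` is the next one to be measured. The change from compound 2 is nitro in place of methoxy on an aromatic carbon. With a single number to lean on, the direction of the step cannot be read from any neighbour; a moderate move beyond the scatter in either direction is plausible, and a loss of the response altogether cannot be excluded.

Compound 4 is expected to give about 5000 nM, with a likely range from 1500 nM to 20000 nM. The expected step of a 1.3-fold higher number from compound 2 to compound 4 (0.13 log units; within the scatter) is judged to be small.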

Compound 4, half-maximal effective concentration: "not active" (no number reported)
The entry for compound 4 holds no number; the estimate stays without a comparison.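

In this assay, among these compounds, compound 4 gives "not active" (no number reported) and carries no number, so no step from compound 2 can be read. The compounds shown leave open whether any group other than methoxy at this place on the shared core gives a measurable response. No measured evidence bears on this result.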